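The source may report more compounds than this note shows. Statements on the series, on what has been measured and on what is new or still open speak of the compounds shown alone.

Compound 1 `CC(C)(C)Cc1c(Br)sc(N)c1C(=O)c1ccc(Cl)cc1` and compound 2 `CC(C)(C)Cc1c(Br)sc(N)c1C(=O)c1ccc(Cl)c(Cl)c1` share one core, and compound 2 differs only by a chloro in place of hydrogen on an aromatic carbon. In an assay on CHO cells for displacement of a labelled ligand from adenosine receptor A1 (Homo sapiens), read by scintillation counting, tested at 10 uM (a lower number here means less inhibition, a higher number more inhibition at the concentration tested (going by the name of the read-out)), compound 1 gives 1%, and compound 2 gives 1%. The step of no change at the digits printed from compound 1 to compound 2 (within the scatter) is flat, so compound 2 stands level with compound 1, and both sit at the floor of the scale, displacing almost none of the labelled ligand at the concentration tested.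

Compound 3 `CC(C)(C)Cc1c(-c2ccccc2)sc(N)c1C(=O)c1ccc(Cl)c(Cl)c1` follows from compound 2 by the change (phenyl in place of bromo on an aromatic carbon). Among the measured compounds shown here, a bromo gives way to a phenyl, a larger alteration than the one separating compound 1 from compound 2. For the measured compounds named here, no measured step touches this position or this kind of exchange; the only guide is no change at the digits printed from compound 1 to compound 2 (within the scatter), which shows one change on the shared core leaving the read-out unmoved. Compound 3 is therefore expected to stay near the floor, with the step of a number 4 percentage points higher from compound 2 to compound 3 (within the scatter) expected to remain within the scatter, though the range leaves room for some gain. The estimate for compound 3 in this assay is 5%, between 0% and 25%.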

Compound 3, a percentage reported as inhibition, at one concentration (the size of the read-out at that concentration, not a potency): 1%
Estimate against measurement, compound 3: 4 percentage points above; measured number inside the range.
By their numbers in this assay, from the lowest: compounds 1, 2 and 3 (each within the scatter of the next).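

In this assay, the exchange of bromo for phenyl on the aromatic carbon next to the ring sulfur gives no change at the digits printed from compound 2 to compound 3 (within the scatter). Among the compounds shown here, this is the first measured change at this position, and it shows that a single bromine can be replaced by a six-membered aromatic ring of six carbons without moving the read-out, whereas the earlier pair showed this only for a chloro in place of hydrogen at another place. The flat result has limited reach, however: all three compounds sit at the floor of the scale, so a change here that weakened binding could hardly show up, and nothing measured alongside these numbers helps to interpret the result.

The compounds shown leave open whether any group on this carbon can lift the read-out off the floor, for example an amine, a carboxylic acid or a longer chain in place of the phenyl. They also leave open whether replacing the neopentyl group or the amino group would do so, since neither has been varied among these three compounds.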